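Working notes on a shared core: compounds 1, 2, 3

This account rests on a few compounds, and the source may have more. Where it says the series, first, only, none or still open, it means among the compounds named here.

Measured so far in a functional assay on COLO 205 cells (Homo sapiens) for inhibition, read by sulforhodamine B assay, with a stated time of 48 h; a higher number here means that more compound is tolerated, a lower number that less compound is tolerated:
- compound 1 `Nc1cc(N)c2nc(-c3ccccc3)c(Oc3ccc(Cl)c(Cl)c3)nc2c1`: < 100000 nM, a limit of the assay, not a number
- compound 2 `COc1cc(CNc2nc3cc(N)cc(N)c3nc2-c2ccccc2)cc(OC)c1OC`: < 50200 nM, also a limit, not a number

Compound 1 therefore stands nowhere definite on the numbers shown: in this assay compound 1 gives only < 100000 nM, which is a limit. The same holds for compound 2, whose value < 50200 nM in this assay is likewise a limit. Going by the values given here, with only the two limits the limit of < 100000 nM in this assay, at which 1 of the 2 values shown sits, and the limit of < 50200 nM in this assay, at which 1 of the 2 values shown sits, in hand, no step between measured compounds can be computed and no ranking is possible.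

Compound 3 `Nc1cc(N)c2nc(-c3ccccc3)c(Oc3ccc(F)cc3)nc2c1` is not yet measured. It differs from compound 1 by 4-fluorophenyl in place of 3,4-dichlorophenyl on an oxygen on an aromatic ring; read one bond further out, 3,4-dichlorophenoxy becomes 4-fluorophenoxy.

Among the compounds with values here, no measured step guides this change, and the starting point is itself a limit, so no direction beyond the scatter is expected for a step that the limit leaves unreadable from compound 1 to compound 3; the estimate is set wide. Compound 3 is expected to give about 30000 nM in this assay, within 5000 nM to 100000 nM, with a real chance that only a limit is again reported.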

Compound 3, concentration lethal to 50% of the cells: 66100 nM
For compound 3 the middle estimate is 2.2-fold (0.34 log units) below the measured one; the range from low to high includes it.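

In this assay, going by these compounds alone, compound 1 gives < 100000 nM, which is a limit and not a number, so no step from compound 1 to compound 3 can be read. The compounds shown leave open whether 4-fluorophenyl in place of 3,4-dichlorophenyl on an oxygen on an aromatic ring shifts the value in this assay, and in which direction.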